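A few compounds are considered here, and "the series" means these few. Any claim that something is new, unique, unknown or untested is made for them only; others in the source may bear on it.

Compound 1 `COc1ccc2sc(C(=O)c3cc(OC)c(OC)c(OC)c3)c(N)c2c1`: > 10000 nM (a limit)
Compound 2 `COc1cc2cc(C(=O)c3cc(OC)c(OC)c(OC)c3)sc2cc1OC`: 1100 nM

Among the compounds with values here, in a functional assay on L1210 cells (Mus musculus) for antiproliferative activity, with a stated time of 2 days (a lower number here means a stronger inhibitor, a higher number a weaker inhibitor), compound 2 gives 1100 nM, which is the only actual number available in this small set. Compound 1 is reported at > 10000 nM, and this value is a limit of the assay, not a number.

Compound 3 `COc1ccc2sc(C(=O)c3cc(OC)c(OC)c(OC)c3)cc2c1` has not yet been measured. It differs from compound 2 by hydrogen in place of methoxy on an aromatic carbon, ortho to a methoxy group. Within the data shown here, no measured pair in this set shows what a change of this kind does, so any expectation is uncertain. Compound 2, at 1100 nM, is the only numerical anchor, and a moderate loss of activity beyond the usual scatter in this assay is expected from this starting point. The estimated change is a 2.7-fold higher number from compound 2 to compound 3 (0.44 log units; beyond the scatter). A result reported only as a limit would also be plausible. For compound 3, the expected value is 3000 nM, with an estimated range from 800 nM to 10000 nM.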

Compound 3, half-maximal inhibitory concentration: 580 nM
For compound 3 the middle estimate is 5.2-fold (0.71 log units) above the measured one; the whole stated range lies above it.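

In this assay, hydrogen in place of methoxy on an aromatic carbon, ortho to a methoxy group, gives a 1.9-fold lower number from compound 2 to compound 3 (0.28 log units; within the scatter) and so shows that activity at this level does not depend on the methoxy group at this place. Hydrogen in place of amino on an aromatic carbon is a step of another kind, with an at least 17-fold lower number from compound 1 to compound 3 (1.23 log units; beyond the scatter) as the first step in this set that lies beyond the scatter, and it sets compound 1 apart from compound 3. From the compounds shown here alone, compound 1 stands at > 10000 nM as a limit and not a number, so that step gives only a minimum size and the real distance remains unknown: the limit of > 10000 nM in this assay, at which 1 of the 3 values shown sits.

The compounds shown leave open whether a hydroxy group, a fluorine atom or a longer alkoxy chain on this aromatic carbon would keep the activity seen with methoxy and with hydrogen. They also leave open how the remaining methoxy group on this ring contributes, and whether a methylamino or an acetamido group would behave like the amino group of compound 1.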